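From compound 1 to compound 4: adding methoxy

A few compounds are considered here, and "the series" means these few. Any claim that something is new, unique, unknown or untested is made for them only; others in the source may bear on it.

Compound 1 `c1ccc(Nc2ccc3ccccc3n2)nc1`: > 30000 nM (a limit)
Compound 2 `Cc1ccnc(Nc2ccc3ccccc3n2)c1`: 26700 nM
Compound 3 `Clc1ccnc(Nc2ccc3ccccc3n2)c1`: > 30000 nM (a limit)

In a functional assay on PC-3 cells (Homo sapiens) for antiproliferative activity, read by MTT assay, with a stated time of 96 h (a lower number here means a stronger inhibitor of growth, a higher number a weaker inhibitor of growth), compound 1 gives only a limit, > 30000 nM. This is the limit of > 30000 nM in this assay, at which 2 of the 3 values shown sit.

Compound 4 `COc1cccc2ccc(Nc3ccccn3)nc12` differs from compound 1 by one change: methoxy in place of hydrogen on an aromatic carbon. Among the compounds with values here, no methoxy step has been measured, so methyl and chloro are the nearest guides. Methyl gave an at least 1.1-fold lower number from compound 1 to compound 2 (0.05 log units; that floor lies within the scatter). Chloro gave a step that the two limits leave unreadable from compound 1 to compound 3. Swapping methyl for chloro gave an at least 1.1-fold higher number from compound 2 to compound 3 (0.05 log units; that floor lies within the scatter). None of these shows a step beyond the scatter, although the limits hide their true sizes. Within the data shown here, compound 2, at 26700 nM, offers the only exact number, so no step beyond the scatter is expected here. The estimated change is an at least 1.2-fold lower number from compound 1 to compound 4 (0.07 log units; that floor lies within the scatter). For compound 4 the expected value is 25000 nM, with an estimated range of 8000 nM to 30000 nM.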

Compound 4, concentration for 50% growth inhibition: 7470 nM
Estimate against measurement, compound 4: 3.3-fold (0.52 log units) above, outside the stated range (below it).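

In this assay, within the data shown here, methoxy on this aromatic carbon, ortho to a fused ring and meta to a fused ring, gives the first step beyond the scatter: an at least 4.0-fold lower number from compound 1 to compound 4 (0.60 log units; beyond the scatter). Neither compound 2 nor compound 3 showed a step of that kind. This size is only a floor, as compound 1 gives only a limit: the limit of > 30000 nM in this assay, at which 2 of the 4 values shown sit.

The compounds shown hold no other group on this carbon and no methoxy on any other, so it stays open whether the gain belongs to methoxy or to this place. As far as these compounds go, whether a hydroxy group, an amine or a longer chain such as ethoxy would do as well also stays open.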